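Working notes on the step to compound 3

The compounds below may be only part of what the source reports. "The series", "measured", "known", "first", "only" and "open" are said of these compounds alone.

- compound 1 `O=C1c2ccccc2C(=O)N1CCOC(=S)N(C(=O)c1ccc(Cl)c(Cl)c1)c1ccccc1` gives 52000 nM
- compound 2 `Cc1ccc(N(C(=O)c2c(F)cccc2F)C(=S)OCCN2C(=O)c3ccccc3C2=O)cc1` gives 65000 nM

In an ADME assay on MT4 cells (Homo sapiens) for cytotoxicity, read by MTT assay (a higher number here means that more compound is tolerated, a lower number that less compound is tolerated), compound 2 stands level with compound 1, their values lying within the scatter of each other. Compound 3 `Cc1ccc(N(C(=O)c2ccc(Cl)c(Cl)c2)C(=S)OCCN2C(=O)c3ccccc3C2=O)cc1` has 3,4-dichlorophenyl in place of 2,6-difluorophenyl on a carbonyl carbon. Among the compounds with values here, no measured step isolates this change. Compound 1 also carries 3,4-dichlorophenyl and gives 52000 nM in the same range, so no shift beyond the scatter is expected in this assay, in either direction. The expected 1.2-fold lower number from compound 2 to compound 3 (0.07 log units; within the scatter) is small. The estimate for compound 3 is 55000 nM (expected range 27000 nM to 110000 nM).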

Compound 3, half-maximal cytotoxic concentration: 17000 nM
The estimate for compound 3 lay 3.2-fold (0.51 log units) above the measured number; the whole stated range lies above it.
By their numbers in this assay, from the lowest: compound 3; then compounds 1 and 2 (each within the scatter of the next).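

In this assay, 3,4-dichlorophenyl in place of 2,6-difluorophenyl on a carbonyl carbon gives a step beyond the scatter (a 3.8-fold lower number from compound 2 to compound 3 (0.58 log units; beyond the scatter)), so the group at this position bears on how much compound is tolerated. With 3,4-dichlorophenyl in place, methyl in place of hydrogen on an aromatic carbon also gives a step beyond the scatter (a 3.1-fold lower number from compound 1 to compound 3 (0.49 log units; beyond the scatter)), so a second place in the series counts as well. Nothing shown accounts for either step.

On these data alone, whether the methyl step carries over when 2,6-difluorophenyl sits on the carbonyl carbon remains open. So does the outcome of methoxy or a carboxylic acid in place of that methyl.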